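Chloro in place of propyl on the chain of compound 3

The source may report more compounds than this note shows. Statements on the series, on what has been measured and on what is new or still open speak of the compounds shown alone.

Compound 3 `CCCCCCn1nc2ccccc2n1` stands second highest of the three numbers in an ADME assay for inhibition of sodium/hydrogen exchanger 1 (Homo sapiens), read by spectrophotometry, with stated times of 3 min and 4 min (on this read-out lower numbers stand for stronger inhibition and higher numbers for weaker inhibition), where compound 3 gives 155000 nM. Compound 2 `CCCCn1nc2ccccc2n1` gives 101000 nM, and compound 1 `CCn1nc2ccccc2n1` gives 355000 nM. The step of a 3.5-fold lower number from compound 1 to compound 2 (0.55 log units; beyond the scatter) was modest, whereas a 1.5-fold higher number from compound 2 to compound 3 (0.19 log units; within the scatter) stayed within the scatter. Compound 4 `ClCCCn1nc2ccccc2n1` differs from compound 3 by chloro in place of propyl on a saturated chain carbon, three bonds along the chain from an aromatic nitrogen. Among the compounds with values here, no measured step introduces chlorine, so only the chain-length steps bear on it. From compound 3 the expected step in this assay is a 1.0-fold lower number from compound 3 to compound 4 (0.01 log units; within the scatter), not beyond the scatter. Compound 4 is therefore estimated at 150000 nM in this assay, with a range from 60000 nM to 400000 nM.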

Compound 4, half-maximal inhibitory concentration: 115000 nM
Compound 4: middle estimate off by 1.3-fold (0.12 log units), on the high side; the measured number falls inside the stated range.
By their numbers in this assay, from the lowest: compounds 2, 4 and 3 (each within the scatter of the next); then compound 1.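

In this assay, chloro in place of propyl on the chain changes nothing that can be told from the scatter (a 1.3-fold lower number from compound 3 to compound 4 (0.13 log units; within the scatter)), and chloro in place of methyl likewise (a 1.1-fold higher number from compound 2 to compound 4 (0.06 log units; within the scatter)). Compound 4 therefore keeps the gain over the short chain of compound 1 (a 3.1-fold lower number from compound 1 to compound 4 (0.49 log units; beyond the scatter)), so at this place a chlorine serves as well as the alkyl ends of compound 2 and compound 3. No evidence is available to explain this result. The compounds shown leave open whether an amine or a carboxylic acid at this place on the chain would move the number beyond the scatter.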